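Methoxy on the Phenyl Ring of Compound 1

The source may hold more compounds than are shown below. What is called first, only, known or untested is meant among the compounds shown, and "the series" means these compounds.

Measured so far:
- compound 1 `Cc1cc(NC(=O)Cn2nnc(-c3ccccc3)n2)n(C2CCCCC2)n1`: 92%
- compound 2 `CC1(c2cc(NC(=O)Cn3nnc(-c4ccccc4)n3)n(C3CCCCC3)n2)CC1`: > 10%
- compound 3 `O=C(Cn1nnc(-c2ccccc2)n1)Nc1cc(C2(C(F)(F)F)CC2)nn1C1CCCCC1`: "not active" (no number reported)

Among the compounds with values here, in an assay on HEK293 cells for activation of Kir3.1/Kir3.2 (Homo sapiens), read by thallium flux (on this read-out higher numbers stand for larger maximal responses and lower numbers for smaller maximal responses), compound 1 gives 92%, the only plain number in this small set. Compound 2 is reported only as a limit of the assay, > 10%. Compound 3 is recorded as "not active" (no number reported), without a number. The step that the limit leaves unreadable from compound 1 to compound 2 therefore cannot be sized, since compound 2 sits at the limit of > 10% in this assay, at which 1 of the 3 values shown sits.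

Compound 4 `COc1ccc(-c2nnn(CC(=O)Nc3cc(C)nn3C3CCCCC3)n2)cc1` differs from compound 1 in one place: methoxy in place of hydrogen on an aromatic carbon. Both measured steps concern the group on the shared core, not the phenyl ring, so none of them bears on this change, and there is no measured comparison to set its size or direction. The expectation rests on compound 1 alone and is a rough one. Compound 4 is estimated at 80%, within 40% to 100%, which means the expected step of a number 12 percentage points lower from compound 1 to compound 4 (beyond the scatter) lies near the scatter.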

Compound 4, largest response reached (Emax), in percent of the reference or control that the assay uses: 90%
The estimate for compound 4 lay 10 percentage points below the measured number, and the stated range covers the measured number.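

In this assay, the phenyl ring of the shared core tolerates a substituent at this place, at least for this one group: going from phenyl to 4-methoxyphenyl gives a number 2 percentage points lower from compound 1 to compound 4 (within the scatter) in the maximal response. Within the data shown here, this is the first readable comparison on the phenyl ring, since the earlier compounds vary only the group that carries the methyl in compound 1. Adding methoxy para to a large group therefore leaves compound 4 indistinguishable from compound 1 on this read-out, so this position does not need to stay unsubstituted to keep a large response.

Going by these compounds, whether an amine, a carboxylic acid or a longer chain such as butoxy would be tolerated at the same place remains open, as does the effect of methoxy elsewhere on the ring. Nothing shown here explains why the response holds with methoxy at this place.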